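This account rests on a few compounds, and the source may have more. Where it says the series, first, only, none or still open, it means among the compounds named here.

Compound 1 `C=C1C(=O)[C@@]23C(=O)OC[C@]4(C(=O)CCC(C)(C)[C@H]4C=O)[C@@H]2CC[C@@H]1[C@H]3O` carries a free hydroxy group on its core, and in a functional assay on K562 cells (Homo sapiens) for cytotoxicity, read by MTT assay, with a stated time of 72 h (a higher number here means a weaker inhibitor, a lower number a stronger inhibitor), compound 1 gives 2180 nM. That is the lowest of the three numbers on hand, although neither of its companions is separated from it by more than the ordinary scatter of this kind of measurement. Compound 2 `C=C1C(=O)[C@@]23C(=O)OC[C@]4(C(=O)CCC(C)(C)[C@H]4C=O)[C@@H]2CC[C@@H]1[C@H]3OC(=O)c1ccc(C(F)(F)F)cc1` gives 2820 nM and compound 3 `C=C1C(=O)[C@@]23C(=O)OC[C@]4(C(=O)CCC(C)(C)[C@H]4C=O)[C@@H]2CC[C@@H]1[C@H]3OC(=O)c1ccccc1F` gives 2860 nM. The steps connecting them are small: a 1.3-fold higher number from compound 1 to compound 2 (0.11 log units; within the scatter), a 1.3-fold higher number from compound 1 to compound 3 (0.12 log units; within the scatter), and a 1.0-fold higher number from compound 2 to compound 3 (0.01 log units; within the scatter).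

Compound 4 `C=C1C(=O)[C@@]23C(=O)OC[C@]4(C(=O)CCC(C)(C)[C@H]4C=O)[C@@H]2CC[C@@H]1[C@H]3OC(=O)c1ccc(Cl)cc1` differs from compound 1 in one place: (4-chlorophenyl)carbonyl in place of hydrogen on an oxygen on a saturated carbon. The two measured steps that bear on this change both attach an aromatic acyl group to the same oxygen, and both stayed within the scatter, as the steps from compound 1 to compound 2 and from compound 1 to compound 3 show. A third aromatic acyl group at that oxygen is therefore expected to behave in the same way, and the step of a 1.2-fold higher number from compound 1 to compound 4 (0.09 log units; within the scatter) is expected to fall within the scatter. On that basis the number for compound 4 is estimated at 2700 nM, with a range from 1500 nM to 5000 nM.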

Compound 4, half-maximal inhibitory concentration: 1380 nM
Beside the measured number, compound 4's estimate is 2.0-fold (0.29 log units) above it; the whole stated range lies above it.
By their numbers in this assay, from the lowest: compounds 4, 1, 2 and 3 (each within the scatter of the next, the first and the last beyond it).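

The third acyl group at this oxygen confirms the earlier picture: with (4-chlorophenyl)carbonyl in place of hydrogen, a 1.6-fold lower number from compound 1 to compound 4 (0.20 log units; within the scatter) stays within the scatter, so in this assay the hydroxy group can carry this larger ester without a clear change in the number. Among these compounds, what is new is that the aromatic group on the carbonyl carbon can matter, whereas the only earlier comparison of two such groups showed no difference beyond the scatter. Here a 2.1-fold lower number from compound 3 to compound 4 (0.32 log units; beyond the scatter) and a 2.0-fold lower number from compound 2 to compound 4 (0.31 log units; beyond the scatter) both pass the scatter, though both steps are modest. Compound 4 is not separated from compound 1 beyond the scatter, so it cannot be called the most potent of the four.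

Nothing measured here accounts for why the 4-chlorophenyl ester stands apart from the other two esters. It also remains open whether a 4-methoxyphenyl group on the same carbonyl, a non-aromatic acetyl group on this oxygen, or an amine in place of the hydroxy group would follow the esters shown or move the number further.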